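A few compounds are considered here, and "the series" means these few. Any claim that something is new, unique, unknown or untested is made for them only; others in the source may bear on it.

Compound 1 `CCOC(=O)C12C(=O)OCC=C1COC2c1ccc(F)cc1` in a functional assay on HeLa cells (Homo sapiens) for cytotoxicity, read by MTT assay (on this read-out higher numbers stand for weaker inhibition and lower numbers for stronger inhibition), gives 22900 nM. Compound 2 `CCOC(=O)C12C(=O)OCC=C1COC2c1ccc(OC)cc1` in this assay gives 18300 nM.

Compound 1 is not separated from compound 2: a 1.3-fold lower number from compound 1 to compound 2 (0.10 log units; within the scatter). Compound 3 `CCOC(=O)C12C(=O)OCC=C1COC2c1cccs1` carries thiophen-2-yl in place of 4-fluorophenyl on a saturated ring carbon. Going by the values given here, no measured step changes the ring itself; the only step known, from compound 1 to compound 2, swaps one substituent on that ring and stays within the scatter. Compound 3 is therefore expected to show no step beyond the scatter in this assay, a 1.1-fold lower number from compound 1 to compound 3 (0.06 log units; within the scatter). Compound 3 is estimated at 20000 nM, between 7000 nM and 60000 nM.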

Compound 3, half-maximal inhibitory concentration: 30400 nM
Beside the measured number, compound 3's estimate is 1.5-fold (0.18 log units) below it; low and high end bracket the measured number.
By their numbers in this assay, from the lowest: compounds 2, 1 and 3 (each within the scatter of the next).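

Exchanging the whole aromatic ring, not just a substituent on it, still yields no separation in this assay: thiophen-2-yl in place of 4-fluorophenyl gives a 1.3-fold higher number from compound 1 to compound 3 (0.12 log units; within the scatter), within the scatter. On this saturated ring carbon, then, a five-membered aromatic ring with one hetero atom and a six-membered aromatic ring of carbon only cannot be told apart. Nothing available explains the size of this step.

The compounds shown leave open whether a non-aromatic group at this carbon, such as an amine or a cyclohexyl group, would move the number beyond the scatter. They also leave open what a carboxylic acid in place of the ethoxycarbonyl group would do.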